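The source may hold more compounds than are shown below. What is called first, only, known or untested is meant among the compounds shown, and "the series" means these compounds.

Four compounds share one core: compound 1 `CC(C)Oc1cccc(-c2csc(NC(=O)c3ccc([N+](=O)[O-])o3)n2)c1`, compound 2 `O=C(Nc1nc(-c2cccc(NC(=O)C3CCC3)c2)cs1)c1ccc([N+](=O)[O-])o1`, compound 3 `O=C(Nc1nc(-c2cccc(NC(=O)C3CCCC3)c2)cs1)c1ccc([N+](=O)[O-])o1` and compound 4 `O=C(Nc1cccc(-c2csc(NC(=O)c3ccc([N+](=O)[O-])o3)n2)c1)c1ccccc1`. In an ADME assay on Vero cells (Chlorocebus sabaeus) for cytotoxicity, read by MTT assay, with a stated time of 72 h (on this read-out lower numbers stand for stronger inhibition and higher numbers for weaker inhibition), compound 1 gives 69500 nM. For compound 2 this assay reports "not determined" (no result reported). On these data alone, compound 3 likewise stands without a number, as this assay reports "not determined" (no result reported) for it, so its own place on the read-out is unknown. The change to compound 4 is phenyl in place of cyclopentyl on a carbonyl carbon. For the measured compounds named here, no measured step of this kind exists here, so the size and direction of the shift in this assay from compound 3 to compound 4 remain open; the expectation is a step no larger than the scatter. Compound 4 is expected to give about 60000 nM, between 20000 nM and 150000 nM.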

Compound 4, half-maximal inhibitory concentration: 50200 nM
Compound 4: the middle estimate sits 1.2-fold (0.08 log units) above what was measured; the measured number falls inside the stated range.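

Read on this assay benzamido in place of isopropoxy on an aromatic carbon gives a 1.4-fold lower number from compound 1 to compound 4 (0.14 log units; within the scatter) and so leaves the number level with that of the isopropoxy compound. For the compounds shown here, compound 4 thus provides the first number for an amide at this place on the shared core, and it shows that a benzamido group can stand here without a shift beyond the scatter.

On these data alone, compound 3 has no number, so the steps to compound 4 from the amides without a number cannot be read, and what an amine or a carboxylic acid would do at this place stays open. No measurement at hand offers an explanation for this result.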